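The source may report more compounds than this note shows. Statements on the series, on what has been measured and on what is new or still open speak of the compounds shown alone.

Of the compounds shown here, three built on one shared core have been tested in an ADME assay on HepG2 cells (Homo sapiens) for cytotoxicity, read by luminescence, CellTiter-Glo and ATP content, with a stated time of 72 h; on this read-out lower numbers stand for an effect already at smaller amounts and higher numbers for an effect only at larger amounts of compound. Compound 1 `Fc1ccc(-c2ccc3c(NCCCNCc4ccco4)ccnc3c2)cc1` gives 7760 nM, compound 2 `CN(C)c1cccc(Oc2ccc3c(NCCCNCc4ccco4)ccnc3c2)c1` gives 16000 nM, and compound 3 `COc1ccc(F)cc1CNCCCNc1ccnc2cc(Oc3cccc(N(C)C)c3)ccc12` gives 3300 nM. Compound 2 thus carries the highest number of the three: the step of a 2.1-fold higher number from compound 1 to compound 2 (0.31 log units; beyond the scatter) is modest, and the step of a 4.8-fold lower number from compound 2 to compound 3 (0.69 log units; beyond the scatter) is modest as well. Compound 4 `COc1ccccc1Oc1ccc2c(NCCCNCc3ccco3)ccnc2c1` has not yet been measured. It differs from compound 2 in one place: 2-methoxyphenyl in place of 3-(dimethylamino)phenyl on an oxygen on an aromatic ring. Within the data shown here, of the measured steps, only the one from compound 1 to compound 2 concerns the same place, the group carried on an oxygen on an aromatic ring, and it was modest; the step from compound 2 to compound 3 lies elsewhere on the molecule and gives little guidance here. A modest step in either direction, or none beyond the scatter, is therefore expected in this assay. Compound 4 is expected to give about 10000 nM, within a range from 4000 nM to 25000 nM, which would mean an expected step of a 1.6-fold lower number from compound 2 to compound 4 (0.20 log units; within the scatter).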

Compound 4, half-maximal effective concentration: 6500 nM
Beside the measured number, compound 4's estimate is 1.5-fold (0.19 log units) above it; low and high end bracket the measured number.
By their numbers in this assay, from the lowest: compounds 3, 4 and 1 (each within the scatter of the next, the first and the last beyond it); then compound 2.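

In this assay, among these compounds, exchanging one substituted phenyl on the oxygen for another gives a 2.5-fold lower number from compound 2 to compound 4 (0.39 log units; beyond the scatter), so this place responds to what the phenoxy ring carries, and not only to the change from 4-fluorophenyl to a phenoxy group that the earlier compounds showed. Putting 2-methoxyphenoxy in place of 4-fluorophenyl gives a 1.2-fold lower number from compound 1 to compound 4 (0.08 log units; within the scatter), so a phenoxy group at this place does not by itself separate a compound from compound 1, and of the two phenoxy groups only 3-(dimethylamino)phenoxy has a step beyond the scatter from 4-fluorophenyl. Nothing available explains these steps.

An unsubstituted phenoxy group would show whether the dimethylamino or the methoxy group accounts for the step between the two phenoxy compounds, and a phenoxy carrying a carboxylic acid or a nitrile would test how far this place can vary. From the compounds shown here alone, it also remains open whether 5-fluoro-2-methoxyphenyl on the chain would give a similar step with 2-methoxyphenoxy on the core.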